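A few compounds are considered here, and "the series" means these few. Any claim that something is new, unique, unknown or untested is made for them only; others in the source may bear on it.

Compound 1 `CCOC(=O)N1CC[C@H](c2ccc(Cl)cc2)[C@H]1C(=O)N1CCN(c2ccc(C)cc2[C@@H](N)C(C)C)CC1` is the starting point. For the measured compounds named here, in an assay on HEK293 cells for displacement of a labelled ligand from Melanocortin receptor 4 (Homo sapiens) (a higher number here means a weaker inhibitor, a lower number a stronger inhibitor), compound 1 gives 42 nM, the only single number recorded for it, alongside one further entry that carries no single number. Compound 2 `CCOC(=O)N1CC[C@H](c2ccc(Cl)cc2)[C@@H]1C(=O)N1CCN(c2ccc(C)cc2[C@@H](N)C(C)C)CC1` shares every atom with compound 1 and differs only in the configuration as drawn (the fact that compounds 1 and 2 differ only in the configuration as drawn); in this assay compound 2 gives 11 nM; 16 nM (2 entries) across its repeated entries (the several entries of compound 2 in this assay, 11 nM; 16 nM (2 entries)).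

Compound 3 `CCCC(=O)N1CC[C@H](c2ccc(Cl)cc2)[C@H]1C(=O)N1CCN(c2ccc(C)cc2[C@@H](N)C(C)C)CC1` is the untested partner of compound 1. Going by the values given here, the single change is propyl in place of ethoxy on a carbonyl carbon whose other neighbour is an amide-type nitrogen in a ring, so that an ethoxycarbonyl becomes a propylcarbonyl. Among the compounds with values here, no measured pair here shows what such a swap does, so the expected step of a 1.2-fold higher number from compound 1 to compound 3 (0.08 log units; within the scatter) is small, within the usual scatter, with no clear direction. Compound 3 is therefore estimated at 50 nM, within a range from 18 nM to 140 nM.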

Compound 3, inhibition constant: 52 nM
Beside the measured number, compound 3's estimate is 1.0-fold (0.02 log units) below it; low and high end bracket the measured number.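

In this assay, propyl in place of ethoxy on a carbonyl carbon gives a 1.2-fold higher number from compound 1 to compound 3 (0.09 log units; within the scatter), a step within the usual scatter, so the two compounds cannot be told apart here. For the compounds shown here, this is the first measured change at this position, and it shows that the oxygen of the ethoxy group, the one hydrogen-bond acceptor in the group that leaves, can be replaced by carbon in compound 1 without a difference this assay can resolve. Nothing among the measurements shown explains why these two groups read alike.

The compounds shown leave open whether the same swap would read alike on compound 2, which has the other configuration as drawn. They also leave open whether an amine or a longer chain such as hexyl on this carbonyl carbon would stay within the scatter of compound 1.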